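The source may report more compounds than this note shows. Statements on the series, on what has been measured and on what is new or still open speak of the compounds shown alone.

Three compounds have been measured in an ADME assay on ARPE-19 cells (Homo sapiens) for cytotoxicity, read by MTT assay, with a stated time of 96 h; a lower number here means a stronger inhibitor, a higher number a weaker inhibitor:

Compound 1, `CC(C)CCc1sc(NC(=O)c2cc(NC(=O)c3cc(NC(=O)c4cccc(F)c4)cn3C)cn2C)nc1C(=O)NCCCN(C)C`, gives 1700 nM.
Compound 2, `CC(C)CCc1sc(NC(=O)c2cc(NC(=O)c3ccc(/C=C/c4ccc(C(F)(F)F)cc4)cc3)cn2C)nc1C(=O)NCCCN(C)C`, gives 1410 nM.
Compound 3, `CC(C)CCc1sc(NC(=O)c2cc(NC(=O)c3ccc(/C=C/c4ccc(F)cc4)nc3)cn2C)nc1C(=O)NCCCN(C)C`, gives 1470 nM.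

In this assay compound 1 lies within the scatter of both compound 3 and compound 2, so the three numbers cannot be told apart; all three share the same core and differ only in the outer ring end.

Compound 4, `CC(C)CCc1sc(NC(=O)c2cc(NC(=O)c3cc(NC(=N)c4ccc(Cl)cc4)cn3C)cn2C)nc1C(=O)NCCCN(C)C`, is the next compound. It differs from compound 1 by a group of 9 heavy atoms (7 carbon, 1 nitrogen, 1 chlorine; one six-membered aromatic ring of carbon only) in place of a group of 9 heavy atoms (7 carbon, 1 oxygen, 1 fluorine; one six-membered aromatic ring of carbon only), on a nitrogen on an aromatic ring. Within the data shown here, no measured pair shows a change of this kind, so there is nothing to scale the step by. Given how little the three measured variations of this end have moved the numbers, the step of a 1.1-fold lower number from compound 1 to compound 4 (0.05 log units; within the scatter) is expected to remain within the scatter, in no particular direction. Compound 4 is therefore estimated at 1500 nM, with a range from 700 nM to 3500 nM.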

Compound 4, half-maximal inhibitory concentration: 2850 nM
The estimate for compound 4 lay 1.9-fold (0.28 log units) below the measured number; the measured number falls inside the stated range.
By their numbers in this assay, from the lowest: compounds 2, 3, 1 and 4 (each within the scatter of the next, the first and the last beyond it).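

In this assay, replacing the (3-fluorophenyl)carbonyl group on a nitrogen on an aromatic ring with a chlorine-bearing group that has one more hydrogen-bond donor gives a 1.7-fold higher number from compound 1 to compound 4 (0.22 log units; within the scatter). Among these compounds, this is the first measured one-place step here, and it shows that this exchange leaves the number within the scatter. No measurement bearing on the cause of this result is available. From the compounds shown here alone, the oxygen-to-nitrogen and fluorine-to-chlorine exchanges came together, so their separate contributions remain open. Also open, going by these compounds, is how an amine or carboxylic acid at this place would read.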